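Acyl for methyl on an oxygen: outlook for compound 3

This account rests on a few compounds, and the source may have more. Where it says the series, first, only, none or still open, it means among the compounds named here.

Compound 1 `COC/C1=C/C[C@](C)(CCC=C(C)C)/C=C/[C@@H](OC(=O)C=C(C)C)[C@](C)(O)/C=C/C1=O` has the lowest of the two numbers in a functional assay on MCF7 cells (Homo sapiens) for antiproliferative activity, read by MTT assay, with a stated time of 48 h (on this read-out lower numbers stand for stronger inhibition and higher numbers for weaker inhibition), giving 4130 nM. Compound 2 `CO[C@]1(C)/C=C/C(=O)/C(CO)=C\C[C@](C)(CCC=C(C)C)/C=C/[C@H]1OC(=O)C=C(C)C` gives 14300 nM in this assay, a gap from compound 1 that lies beyond the scatter. Going by the values given here, no pair differing in a single place has been measured, so the size of a single change is unknown here. Compound 3 `CC(C)=CCC[C@]1(C)/C=C/[C@@H](OC(=O)C=C(C)C)[C@](C)(O)/C=C/C(=O)/C(COC(=O)c2ccc([N+](=O)[O-])cc2)=C\C1` differs from compound 1 by (4-nitrophenyl)carbonyl in place of methyl on an oxygen on a saturated carbon, the methoxy becoming ((4-nitrophenyl)carbonyl)oxy. Lacking any single-change step, the expected step of a 1.2-fold lower number from compound 1 to compound 3 (0.07 log units; within the scatter) is none beyond the scatter, with wide allowance either way. Compound 3 is therefore estimated at 3500 nM, in the range 900 nM to 14000 nM.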

Compound 3, half-maximal inhibitory concentration: 670 nM
Beside the measured number, compound 3's estimate is 5.2-fold (0.72 log units) above it; the whole stated range lies above it.
By their numbers in this assay, from the lowest: compound 3; then compound 1; then compound 2.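

In this assay, the oxygen on a saturated carbon accepts far more than a methyl: (4-nitrophenyl)carbonyl in its place gives the only single-place step shown (a 6.2-fold lower number from compound 1 to compound 3 (0.79 log units; beyond the scatter)), and this step lies beyond the scatter. At this position, a group of 11 heavy atoms with an aromatic ring therefore goes with a lower number, not a loss. No measurement shown accounts for the step.

Still open, from the compounds shown here alone, is whether the lower number depends on the nitro group, the aromatic ring or the carbonyl alone. A plain benzoyl or acetyl on this oxygen would separate these.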